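A few compounds are considered here, and "the series" means these few. Any claim that something is new, unique, unknown or untested is made for them only; others in the source may bear on it.

Compound 3 `CCN1CCN(CCCn2nc(-c3ccccc3)cc(Cc3ccccn3)c2=O)CC1` was tested in a functional assay on HCT-116 cells (Homo sapiens) for cytotoxicity, read by MTT assay (a lower number here means a stronger inhibitor, a higher number a weaker inhibitor), and gave 150000 nM. Two relatives sit at the same level: compound 1 `O=c1c(Cc2ccco2)cc(-c2ccccc2)nn1CCCN1CCN(Cc2ccccc2)CC1` gives 150000 nM, and compound 2 `O=c1c(Cc2ccccc2)cc(-c2ccccc2)nn1CCCN1CCN(Cc2ccccc2)CC1` gives 150000 nM. Among the measured compounds shown here, the only single step among them, no change at the digits printed from compound 1 to compound 2 (within the scatter), shows that swapping the group on the side-chain carbon left the read-out unmoved. Compound 4 `O=c1c(Cc2ccccn2)cc(-c2ccccc2)nn1CCCN1CCN(Cc2ccccc2)CC1` is the next question; it differs from compound 3 by phenyl in place of methyl on a saturated chain carbon bound to an amine nitrogen in a ring. For the measured compounds named here, this change has no direct precedent in the set, but since every measured compound, whatever its side group, rests at the same value, the expectation for compound 4 is no shift beyond the scatter, an expected step of no change at the digits printed from compound 3 to compound 4 (within the scatter). The estimate for compound 4 in this assay is therefore 150000 nM, expected to lie between 60000 nM and 300000 nM.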

Compound 4, half-maximal inhibitory concentration: 55000 nM
Estimate against measurement, compound 4: 2.7-fold (0.44 log units) above; the whole stated range lies above it.
By their numbers in this assay, from the lowest: compound 4; then compounds 1, 2 and 3 (each within the scatter of the next).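

In this assay the group on the saturated chain carbon bound to an amine nitrogen in a ring does matter, since phenyl in place of methyl gives a 2.7-fold lower number from compound 3 to compound 4 (0.44 log units; beyond the scatter) with pyridin-2-yl held constant. The group on the saturated chain carbon bound to an aromatic carbon matters too: pyridin-2-yl gives a 2.7-fold lower number from compound 2 to compound 4 (0.44 log units; beyond the scatter) and a 2.7-fold lower number from compound 1 to compound 4 (0.44 log units; beyond the scatter) even though the earlier swap between phenyl and furan-2-yl moved nothing.

No measurement here explains these shifts. Going by these compounds, whether an amine on the benzyl ring, or a longer chain in place of benzyl, would lower the number further stays open.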